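The compounds below may be only part of what the source reports. "The series", "measured", "known", "first", "only" and "open" are said of these compounds alone.

Cytotoxicity notes on a small set of aminothiazoles. Compound 1 `COc1cccc(Nc2nc(-c3ccccn3)cs2)c1` gives 51200 nM in an ADME assay on KB cells (Homo sapiens) for cytotoxicity, read by MTT assay, with a stated time of 72 h; on this read-out lower numbers stand for higher toxicity in this test and higher numbers for lower toxicity in this test. Compound 2 `COc1ccc(Nc2nc(-c3ccccn3)cs2)cc1OC` gives 62000 nM in this assay; the change between them, (methoxy in place of hydrogen on an aromatic carbon), produced a 1.2-fold higher number from compound 1 to compound 2 (0.08 log units; within the scatter). Compound 3 `Clc1ccc(Nc2nc(-c3ccccn3)cs2)nc1` gives 98600 nM in this assay; the difference between its core and the core of compound 1 is not broken down here. Compound 4 `COc1ccc(-c2csc(Nc3ccc(Cl)cn3)n2)nc1` is not yet measured; it differs from compound 3 by methoxy in place of hydrogen on an aromatic carbon. This is the same kind of change as from compound 1 to compound 2, but the place differs: there the methoxy enters on a six-membered aromatic ring of carbon only, ortho to a methoxy group; here on a six-membered aromatic ring with 1 nitrogen, two atoms from the ring nitrogen. Because a 1.2-fold higher number from compound 1 to compound 2 (0.08 log units; within the scatter) stayed within the scatter, a similarly small step is expected for compound 4, a 1.1-fold higher number from compound 3 to compound 4 (0.05 log units; within the scatter), in this assay. The estimate for compound 4 is 110000 nM, between 55000 nM and 220000 nM.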

Compound 4, half-maximal cytotoxic concentration: 59600 nM
For compound 4 the middle estimate is 1.8-fold (0.27 log units) above the measured one; the measured number falls inside the stated range.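

Methoxy in place of hydrogen on an aromatic carbon gives a 1.7-fold lower number from compound 3 to compound 4 (0.22 log units; within the scatter) in this assay, on a core other than that of compound 1. Set beside the earlier step, the two results do not separate: the same change on two cores in this assay, a 1.2-fold higher number (0.08 log units; within the scatter) from compound 1 to compound 2 and a 1.7-fold lower number (0.22 log units; within the scatter) from compound 3 to compound 4, 2.0-fold (0.30 log units) apart, within the scatter of two such steps. Across these two pairs the change thus carries from one core to the other with no step beyond the scatter, but two such small steps do not show that it would stay this small on further cores or at other places.

Left open is whether a different group on the aromatic carbon para to a large group, such as an amine or a carboxylic acid, would give a step beyond the scatter. Also open is how methoxy behaves on the other rings of these compounds.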